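A few compounds are considered here, and "the series" means these few. Any claim that something is new, unique, unknown or untested is made for them only; others in the source may bear on it.

Measured in a functional assay on HCT-116 cells (Homo sapiens) for antiproliferative activity, read by MTT assay, with a stated time of 72 h; on this read-out higher numbers stand for weaker inhibition and lower numbers for stronger inhibition:

- compound 1 `N=C(NC(=N)NC1CCCC1)Nc1ccc(C(F)(F)F)cc1`: 3800 nM
- compound 2 `CC(C)NC(=N)NC(=N)Nc1ccc(C(F)(F)F)cc1`: 4800 nM
- compound 3 `CCN(CC)C(=N)NC(=N)Nc1ccc(C(F)(F)F)cc1`: 4300 nM

Compound 3, at 4300 nM, lies within the scatter of both compound 1 and compound 2, so the three values show no separation. Compound 4 `CCN(C)C(=N)NC(=N)Nc1ccc(C(F)(F)F)cc1` differs from compound 3 by one change: hydrogen in place of methyl on a saturated chain carbon bound to an amine nitrogen, which turns diethylamino into ethyl(methyl)amino.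

For the measured compounds named here, three measured steps bear on this change, all of them exchanges of the same amino group: a 1.1-fold lower number from compound 2 to compound 3 (0.05 log units; within the scatter), a 1.1-fold higher number from compound 1 to compound 3 (0.05 log units; within the scatter) and a 1.3-fold higher number from compound 1 to compound 2 (0.10 log units; within the scatter). Each stays within the scatter. Going by the values given here, no measured step isolates the loss of this one carbon, but with steps this small, no step beyond the scatter is expected in this assay. The estimate corresponds to an expected 1.0-fold higher number from compound 3 to compound 4 (0.02 log units; within the scatter). For compound 4 the expected value is about 4500 nM, with an estimated range from 2800 nM to 7200 nM.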

Compound 4, half-maximal inhibitory concentration: 4000 nM
Beside the measured number, compound 4's estimate is 1.1-fold (0.05 log units) above it; measured number inside the range.
By their numbers in this assay, from the lowest: compounds 1, 4, 3 and 2 (each within the scatter of the next).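

In this assay the removal of a single carbon can now be read directly: a 1.1-fold lower number from compound 3 to compound 4 (0.03 log units; within the scatter) shows that hydrogen in place of methyl on a saturated chain carbon bound to an amine nitrogen leaves the number within the scatter. The new compound also stays within the scatter of the other two amino groups, with a 1.2-fold lower number from compound 2 to compound 4 (0.08 log units; within the scatter) and a 1.1-fold higher number from compound 1 to compound 4 (0.02 log units; within the scatter), so all four compounds remain unseparated and the change from diethylamino to ethyl(methyl)amino opens no difference at this position. No measurement at hand explains why these values stay together.

The compounds shown leave open whether dimethylamino, or a longer chain ending in a carboxylic acid or a hydroxyl group, would move the number beyond the scatter. They also leave open how much of the activity depends on this amino group at all.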